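Thiazolyl amide replacing a methoxyphenyl amide on a cinnamate ester

The source may hold more compounds than are shown below. What is called first, only, known or untested is meant among the compounds shown, and "the series" means these compounds.

Measured so far:
compound 1 `COCOc1cc(/C=C/C(=O)OCC(=O)Nc2ccc(OC)cc2)ccc1OCc1ccccc1`: > 200000 nM
compound 2 `COc1ccc(NC(=O)COC(=O)/C=C/c2ccc(OCc3ccccc3)c(O)c2)cc1`: > 200000 nM

In a functional assay on ECa-109 cells (Homo sapiens) for cytotoxicity, read by MTT assay, with a stated time of 72 h (a higher number here means a weaker inhibitor, a lower number a stronger inhibitor), compound 1 gives > 200000 nM, which is a limit of the assay and not a number. In this assay compound 2 likewise gives only the limit > 200000 nM. The change from compound 1 to compound 2, hydrogen in place of methoxymethyl on an oxygen on an aromatic ring, gives the step that the two limits leave unreadable from compound 1 to compound 2, which stays unreadable because both values sit at the limit of > 200000 nM in this assay, at which 2 of the 2 values shown sit.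

Compound 3 `COCOc1cc(/C=C/C(=O)OCC(=O)Nc2nccs2)ccc1OCc1ccccc1` differs from compound 1 by 1,3-thiazol-2-yl in place of 4-methoxyphenyl on an amide-type nitrogen. Within the data shown here, no measured step touches this amide-type nitrogen, so nothing among the measured compounds points to a direction in this assay. Compound 3 is therefore expected to remain near the limit, with an estimate of 150000 nM and a range from 40000 nM to 300000 nM. The step of an at least 1.3-fold lower number from compound 1 to compound 3 (0.12 log units; that floor lies within the scatter) is expected to stay within the scatter.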

Compound 3, half-maximal inhibitory concentration: > 200000 nM
Compound 3 ended at the assay's limit; the forecaster's own chance of this, stated with the estimate: 70%; middle value at least 1.3-fold (0.12 log units) from the limit.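

In this assay compound 3 gives > 200000 nM which is a limit of the assay and not a number, and no new step can be read between compound 1 and compound 3: (the limit of > 200000 nM in this assay, at which 3 of the 3 values shown sit). The compounds shown leave open whether 1,3-thiazol-2-yl in place of 4-methoxyphenyl on an amide-type nitrogen has any effect in this assay at all.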